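A few compounds are considered here, and "the series" means these few. Any claim that something is new, unique, unknown or untested is made for them only; others in the source may bear on it.

Of the compounds shown here, two have so far been measured in a functional assay on HepG2 cells (Homo sapiens) for inhibition, read by MTT assay, with a stated time of 72 h; on this read-out higher numbers stand for weaker inhibition and lower numbers for stronger inhibition. Compound 1 `O=C(Nc1ccc(Oc2ccnc3[nH]ccc23)cc1)c1cn(-c2ccccc2)c2ccccc2c1=O` gives 2250 nM in this assay. Compound 2 `Cn1ccc2c(Oc3ccc(NC(=O)c4cn(-c5ccccc5)c5ccccc5c4=O)cc3F)ccnc21` gives 2170 nM in this assay. The two numbers lie within the scatter of one another, so nothing separates compound 2 from compound 1 on what has been measured, and compound 2 stands beside compound 1 rather than apart from it.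

Compound 3 `COc1ccc(-n2cc(C(=O)Nc3ccc(Oc4ccnc5c4ccn5C)c(F)c3)c(=O)c3ccccc32)cc1` is the next member to be tested. It differs from compound 2 by methoxy in place of hydrogen on an aromatic carbon. Among the compounds with values here, no pair of measured compounds shows this change, so there is no step of the kind to draw on, and neither the direction nor the size of any effect can be read from the series. With only the two measured values as a footing, the expected step is a 1.1-fold lower number from compound 2 to compound 3 (0.04 log units; within the scatter), a change of a size that stays within the scatter. In this assay compound 3 is accordingly estimated at 2000 nM, with a range from 800 nM to 5000 nM.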

Compound 3, half-maximal inhibitory concentration: 3750 nM
Compound 3: the middle estimate sits 1.9-fold (0.27 log units) below what was measured; the measured number falls inside the stated range.
By their numbers in this assay, from the lowest: compounds 2, 1 and 3 (each within the scatter of the next).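

Phenyl to 4-methoxyphenyl gives the series its first reading at this position, an aromatic carbon para to a large group: in this assay the change gives a 1.7-fold higher number from compound 2 to compound 3 (0.24 log units; within the scatter) and so stays within the scatter. Compound 3 therefore cannot be separated from compound 2 on this read-out, and methoxy in place of hydrogen at this position is accommodated without an effect that the measurement can resolve. This single step shows neither a direction nor a size for the change, and no supporting measurement is available to account for it.

A single substituent at one position leaves open whether a different group there, such as an amine or a carboxylic acid, would give a step beyond the scatter in this assay or whether any group at this position can move the number at all. Within the data shown here, also open is whether methoxy at this position would give a comparable step on the core of compound 1, since the series holds no pair that shows this change on that core.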